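The source may report more compounds than this note shows. Statements on the series, on what has been measured and on what is new or still open speak of the compounds shown alone.

Compound 2 `Cn1ccc2c(Oc3ccc(NC(=O)c4nn(-c5ccc(Br)cc5)ccc4=O)cc3)ccnc21` gives the highest number of the two measured in a functional assay on A549 cells (Homo sapiens) for cytotoxicity, read by MTT assay, with a stated time of 72 h (on this read-out higher numbers stand for weaker inhibition and lower numbers for stronger inhibition), at 59400 nM. Compound 1 `O=C(Nc1ccc(Oc2ccnc3[nH]ccc23)cc1)c1nn(-c2ccccc2)ccc1=O`, which differs from it in several places, gives 10500 nM in this assay, a gap reported as beyond the scatter. Compound 3 `Cn1ccc2c(Oc3ccc(NC(=O)c4nn(-c5ccccc5)ccc4=O)cc3)ccnc21` is not yet measured. The change from compound 2 is hydrogen in place of bromo on an aromatic carbon. Within the data shown here, with no one-place step measured, a modest move toward the lower number of compound 1 is expected; the step of a 2.7-fold lower number from compound 2 to compound 3 (0.43 log units; beyond the scatter) is an estimate only. Compound 3 is expected at 22000 nM, between 7000 nM and 65000 nM.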

Compound 3, half-maximal inhibitory concentration: 51700 nM
Beside the measured number, compound 3's estimate is 2.4-fold (0.37 log units) below it, and the stated range covers the measured number.
By their numbers in this assay, from the lowest: compound 1; then compounds 3 and 2 (each within the scatter of the next).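

In this assay, 4-bromophenyl to phenyl gives a 1.1-fold lower number from compound 2 to compound 3 (0.06 log units; within the scatter), so bromo and hydrogen cannot be told apart at this place, para to a large group. The one-place step beyond the scatter lies elsewhere: methyl in place of hydrogen on an aromatic nitrogen gives a 4.9-fold higher number from compound 1 to compound 3 (0.69 log units; beyond the scatter). Nothing available explains either step.

From the compounds shown here alone, whether an amine or a carboxylic acid at the para place would separate from compound 3 remains open. So does whether a longer chain on the aromatic nitrogen would extend the step seen with methyl.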